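The source may hold more compounds than are shown below. What is called first, only, known or untested is meant among the compounds shown, and "the series" means these compounds.

Measured in a functional assay on HSC-2 cells (Homo sapiens) for cytotoxicity, with a stated time of 24 h; a higher number here means that more compound is tolerated, a lower number that less compound is tolerated:
- compound 1 `COc1ccc(/C=C2\CCC/C(=C\c3ccccc3[N+](=O)[O-])C2=O)cc1`: 11000 nM
- compound 2 `O=C1/C(=C/c2ccc(F)cc2)CCC/C1=C\c1cccc([N+](=O)[O-])c1`: 2200 nM
- compound 3 `O=C1/C(=C/c2ccc(Cl)cc2)CCC/C1=C\c1cccc([N+](=O)[O-])c1`: 2200 nM

Compound 3 stands level with compound 2, together the lowest of the three values. Next is compound 4 `COc1ccc(/C=C2\CCC/C(=C\c3cccc([N+](=O)[O-])c3)C2=O)cc1`, which keeps the core of compound 3 with one change: methoxy in place of chloro on an aromatic carbon. For the measured compounds named here, the one measured step on this carbon, no change at the digits printed from compound 2 to compound 3 (within the scatter), lies within the scatter. Compound 1 also carries 4-methoxyphenyl and gives 11000 nM, but it differs from compound 3 in more than this one place, so it only stretches the expected range upward. The step expected in this assay is a 1.4-fold higher number from compound 3 to compound 4 (0.13 log units; within the scatter), within the scatter and leaning upward. Compound 4 is estimated at 3000 nM, with an expected range of 1200 nM to 8000 nM.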

Compound 4, half-maximal cytotoxic concentration: 4800 nM
Compound 4: middle estimate off by 1.6-fold (0.20 log units), on the low side; the measured number falls inside the stated range.
By their numbers in this assay, from the lowest: compounds 2 and 3 (each within the scatter of the next); then compound 4; then compound 1.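

In this assay, methoxy on this aromatic carbon moves the number beyond the scatter from both halogen compounds (a 2.2-fold higher number from compound 3 to compound 4 (0.34 log units; beyond the scatter)) and (a 2.2-fold higher number from compound 2 to compound 4 (0.34 log units; beyond the scatter)), whereas exchanging fluoro for chloro did not (no change at the digits printed from compound 2 to compound 3 (within the scatter)). Both steps are modest, so this position tolerates the change with only a small shift in the number. Nothing available bears on the cause of this shift.

Going by these compounds, whether the trend continues with a hydroxy group, an amine or a longer alkoxy chain on this carbon remains open. A single methoxy compound also cannot show whether the shift comes from this group alone.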